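The compounds below may be only part of what the source reports. "The series", "measured", "known", "first", "only" and "open" are said of these compounds alone.

Measured in a functional assay on HCT-15 cells (Homo sapiens) for antiproliferative activity; a higher number here means a weaker inhibitor, a lower number a stronger inhibitor:
- compound 1 `COc1ccc(S(=O)(=O)Oc2ccccc2NC(=O)Nc2ccccc2)cc1`: > 10000 nM, a limit
- compound 2 `COc1ccc(S(=O)(=O)Oc2ccccc2NC(=O)c2ccc(F)cc2)cc1`: 89 nM

Among the measured compounds shown here, compound 2 holds the only actual number. Compound 1 stands at a limit: the limit of > 10000 nM in this assay, at which 1 of the 2 values shown sits.

Compound 3 `COc1ccc(S(=O)(=O)Oc2ccccc2NC(=O)c2ccnc3ccccc23)cc1` carries quinolin-4-yl in place of 4-fluorophenyl on a carbonyl carbon. For the measured compounds named here, one measured step bears on this place: an at least 110-fold lower number from compound 1 to compound 2 (2.05 log units; beyond the scatter). That step is large, but it concerns anilino rather than either group here, so it shows that the place matters without giving a direction. A moderate rise in the number is expected in this assay, estimated as a 3.4-fold higher number from compound 2 to compound 3 (0.53 log units; beyond the scatter). Compound 3 is estimated at 300 nM, with an expected range of 40 nM to 3000 nM.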

Compound 3, half-maximal inhibitory concentration: > 10000 nM
Compound 3 ended at the assay's limit; the forecaster's own chance of this, stated with the estimate: 10%; middle value at least 33-fold (1.52 log units) from the limit.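

In this assay, the position is sensitive to a second replacement, with a known direction: quinolin-4-yl in place of 4-fluorophenyl on the carbonyl carbon gives an at least 110-fold higher number from compound 2 to compound 3 (2.05 log units; beyond the scatter). Anilino is therefore not the only group here that leaves a compound at the limit, and compound 2 alone keeps a measured number: the limit of > 10000 nM in this assay, at which 2 of the 3 values shown sit. The step between compound 1 and compound 3 cannot be read, since both values are limits.

Open, from the compounds shown here alone, is whether plain phenyl or pyridin-4-yl on this carbonyl carbon would keep a number near that of compound 2. Going by these compounds, whether the fluorine itself contributes also remains open.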